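Replacing 4-Fluorobenzyl with 2,6-Dichlorobenzyl

The compounds below may be only part of what the source reports. "The series", "measured", "known", "first", "only" and "open" are said of these compounds alone.

Going by the values given here, in a functional assay on DU-145 cells (Homo sapiens) for cytotoxicity, read by MTT assay (a lower number here means a stronger inhibitor, a higher number a weaker inhibitor), compound 1 (`COc1ccc2cc([C@H](C)c3nnc(SCc4ccc(Cl)cc4)n3-c3ccc(F)cc3)ccc2c1`) gives 57400 nM and compound 2 (`COc1ccc2cc([C@H](C)c3nnc(SCc4ccc(F)cc4)n3-c3ccc(F)cc3)ccc2c1`) gives 60200 nM as the only other number, so compound 2 stands level with compound 1 within the scatter. Compound 3 (`COc1ccc2cc([C@H](C)c3nnc(SCc4c(Cl)cccc4Cl)n3-c3ccc(F)cc3)ccc2c1`) has not yet been measured. It carries 2,6-dichlorophenyl in place of 4-fluorophenyl on a saturated chain carbon bound to a sulfur, so 4-fluorobenzyl becomes 2,6-dichlorobenzyl. Among the compounds with values here, the one measured step that bears on this, a 1.0-fold higher number from compound 1 to compound 2 (0.02 log units; within the scatter) for fluoro in place of chloro on an aromatic carbon, lies within the scatter. Within the data shown here, no measured compound carries 2,6-dichlorobenzyl, so only a small step in this assay is expected, towards a slightly lower number and not clearly beyond the scatter. The expected step is a 1.3-fold lower number from compound 2 to compound 3 (0.13 log units; within the scatter) by this estimate. Compound 3 is expected at 45000 nM in a range from 18000 nM to 100000 nM as estimated here.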

Compound 3, half-maximal inhibitory concentration: 12300 nM
Beside the measured number, compound 3's estimate is 3.7-fold (0.56 log units) above it, and the stated range ends above it.
By their numbers in this assay, from the lowest: compound 3; then compounds 1 and 2 (each within the scatter of the next).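

In this assay, the group on the sulfur is shown to be a place where the number can move: the exchange between 4-chlorobenzyl and 4-fluorobenzyl had stayed within the scatter, but 2,6-dichlorobenzyl gives a 4.9-fold lower number from compound 2 to compound 3 (0.69 log units; beyond the scatter) and a 4.7-fold lower number from compound 1 to compound 3 (0.67 log units; beyond the scatter). The two steps are close in size, so compound 3 stands apart from compounds 1 and 2 alike, and it has the lowest number of the three, though the gain is only modest. Nothing available explains why this change lowers the number.

As far as these compounds go, whether an unsubstituted benzyl, a methoxybenzyl or a plain longer alkyl chain on the sulfur would lower the number further stays open. From the compounds shown here alone, all three compounds share one core, so it is also open whether the step from 2,6-dichlorobenzyl would carry over to another core.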